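Adding a second trifluoromethyl to the amide aryl ring

This account rests on a few compounds, and the source may have more. Where it says the series, first, only, none or still open, it means among the compounds named here.

Measured compounds:
compound 1 `COc1cc(Cl)cc(-c2nn(-c3cccc(NC(=O)c4ccc(Cl)c(Cl)c4)c3)cc2-c2ccncc2)c1` with 77.8%
compound 2 `COc1cc(Cl)cc(-c2nn(-c3cccc(NC(=O)Nc4cccc(C(F)(F)F)c4)c3)cc2-c2ccncc2)c1` with 19%
compound 3 `COc1cc(Cl)cc(-c2nn(-c3cccc(NC(=O)c4cccc(C(F)(F)F)c4)c3)cc2-c2ccncc2)c1` with 54.6%

All three share one core and differ only in the group attached to the carbonyl carbon of the amide. In a functional assay on HCC 2998 cells (Homo sapiens) for inhibition, read by sulforhodamine B assay, with a stated time of 48 h, tested at 10 uM (on this read-out higher numbers stand for a weaker effect at the one concentration tested and lower numbers for a stronger effect), compound 3 stands second highest of the three numbers: it lies a number 23.2 percentage points lower from compound 1 to compound 3 (beyond the scatter) and a number 35.6 percentage points higher from compound 2 to compound 3 (beyond the scatter).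

Compound 4 `COc1cc(Cl)cc(-c2nn(-c3cccc(NC(=O)c4cc(C(F)(F)F)cc(C(F)(F)F)c4)c3)cc2-c2ccncc2)c1` has not yet been measured. Compared with compound 3, its change is trifluoromethyl in place of hydrogen on an aromatic carbon

Among the measured compounds shown here, no measured step adds or removes a single group on this aryl ring, so none bears on the change directly. The closest is the step from compound 1 to compound 3, where the ring carried two halogens before and one trifluoromethyl after; that step was a number 23.2 percentage points lower from compound 1 to compound 3 (beyond the scatter), a modest one. Compound 4 returns to a ring bearing two groups, now both trifluoromethyl. The step from compound 2 to compound 3 concerns the link to the carbonyl rather than this ring and is not informative here.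

The expectation for compound 4 is therefore a small rise in the number, a number 7.4 percentage points higher from compound 3 to compound 4 (within the scatter), which may not exceed the scatter. Compound 4 is estimated at 62%, within a range from 40% to 85%.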

Compound 4, a percentage reported as activity, at one concentration (the size of the read-out at that concentration, not a potency): 78.3%
The estimate for compound 4 lay 16.3 percentage points below the measured number, and the stated range covers the measured number.
By their numbers in this assay, from the lowest: compound 2; then compound 3; then compounds 1 and 4 (each within the scatter of the next).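

Among the compounds shown here, compound 4 gives the first direct look at adding a group to this aryl ring: placing a trifluoromethyl on an aromatic carbon, meta to a large group and meta to the trifluoromethyl already there, moves the read-out in this assay with a number 23.7 percentage points higher from compound 3 to compound 4 (beyond the scatter) and so weakens the effect at the one concentration tested. This open ring carbon is therefore not indifferent to substitution, and among this pair the ring with a single trifluoromethyl and hydrogen at this position gives the stronger effect. No measurement at hand explains the shift.

A single pair cannot show whether the weaker effect follows from any group at this position or is specific to trifluoromethyl, so a fluorine atom, a methyl group or an amine placed on the same carbon would be the informative comparison. As far as these compounds go, it also stays open whether the same addition would shift the read-out in the same direction on compound 2, where a nitrogen links the carbonyl to the aryl ring.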